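Swapping phenoxy for trifluoromethyl in compound 4

The source may report more compounds than this note shows. Statements on the series, on what has been measured and on what is new or still open speak of the compounds shown alone.

Compound 1, `CC(=O)N1CCN(c2ccc(Nc3ncc(C(F)(F)F)c(N4Cc5cccc(N(C)S(C)(=O)=O)c5C4)n3)cc2)CC1`, gives 1400 nM in a functional assay on HepG2 cells (Homo sapiens) for antiproliferative activity, read by spectrophotometry, with a stated time of 2 days; a higher number here means a weaker inhibitor of growth, a lower number a stronger inhibitor of growth.
Compound 2, `CN(c1cccc2c1CN(c1nc(Nc3ccc(Nc4ccccc4)cc3)ncc1C(F)(F)F)C2)S(C)(=O)=O`, gives 8600 nM in the same measurement.
Compound 3, `CN(c1cccc2c1CN(c1nc(Nc3cccc(Oc4ccccc4)c3)ncc1C(F)(F)F)C2)S(C)(=O)=O`, gives 23000 nM in the same measurement.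

Compound 3 stands at the highest number of the three, so it is the weakest inhibitor of growth among them: compound 2 sits at a lower number, and compound 1 lower still. Among the compounds with values here, the only step between compounds that differ in one place is a 6.1-fold higher number from compound 1 to compound 2 (0.79 log units; beyond the scatter); it concerns a different group at a different place and so does not speak directly to the change at hand.

Compound 4, `CN(c1cccc2c1CN(c1nc(Nc3cccc(C(F)(F)F)c3)ncc1C(F)(F)F)C2)S(C)(=O)=O`, differs from compound 3 in one way: trifluoromethyl in place of phenoxy on an aromatic carbon. Within the data shown here, no measured pair shows what this exchange does, so the expectation rests only on where compound 3 stands. Compound 4 is expected to remain a weak inhibitor of growth, with a step of about a 1.9-fold lower number from compound 3 to compound 4 (0.28 log units; within the scatter) toward a lower number, though a result within the scatter of compound 3 would not surprise. Compound 4 is therefore estimated at 12000 nM, with a range from 3000 nM to 40000 nM.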

Compound 4, concentration for 50% growth inhibition: > 30000 nM
Compound 4 was reported as a limit; the forecaster's own chance of this, stated with the estimate: 10%; middle value at least 2.5-fold (0.39 log units) from the limit.
By their numbers in this assay, from the lowest: compound 1; then compound 2; then compound 3. At a limit, above all of these: compound 4.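

In this assay compound 4 gives > 30000 nM as its result, which is a limit of the assay and not a number. The exchange of phenoxy for trifluoromethyl is therefore known only as an at least 1.3-fold higher number from compound 3 to compound 4 (0.11 log units; that floor lies within the scatter), so the two compounds are not firmly separated, and the reading of this step rests on a single value: the limit of > 30000 nM in this assay, at which 1 of the 4 values shown sits. Even so, this is the first look at this aromatic carbon, meta to a large group, and it shows that removing the phenoxy ring in favour of the smaller trifluoromethyl, which has no ring, brings no gain in growth inhibition.

On these data alone, it remains open whether the ring or the oxygen of phenoxy matters more, a question that a directly attached phenyl or a benzyl group at the same carbon could help to settle. As far as these compounds go, it is also open whether a group of a different kind here, such as an amine or a carboxylic acid, would bring the number down toward the lower values of the series.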